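Diphenyl-substituted azine series: sterol O-acyltransferase 1 inhibition

A few compounds are considered here, and "the series" means these few. Any claim that something is new, unique, unknown or untested is made for them only; others in the source may bear on it.

Measured compounds:
- compound 1, `CCCCCCCCCn1nc(-c2ccccc2)c(-c2ccccc2)cc1=O`: 85000 nM
- compound 2, `CCCCCCNc1cc(-c2ccccc2)c(-c2ccccc2)nn1`: 24000 nM
- compound 3, `CCCCCCCCCSc1cc(-c2ccccc2)c(-c2ccccc2)nn1`: 116000 nM

All three were run in an assay on microsomes from liver for inhibition of sterol O-acyltransferase 1 (Rattus norvegicus); a lower number here means a stronger inhibitor, a higher number a weaker inhibitor. Compound 2 gives the lowest number of the three, with compound 1 the nearest and compound 3 the furthest; both gaps lie beyond the usual scatter, so compound 2 is the strongest inhibitor among the measured set. Going by the values given here, no pair of measured compounds differs in a single place, so no step within the measured set can be quoted.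

Compound 4, `CCCCCCC[S+]([O-])c1cc(-c2ccccc2)c(-c2ccccc2)nn1`, is not yet measured. It differs from compound 2 as follows: a group of 9 heavy atoms (7 carbon, 1 oxygen, 1 sulfur; no ring) in place of a group of 7 heavy atoms (6 carbon, 1 nitrogen; no ring), on an aromatic carbon. Among the compounds with values here, the only guidance is that compound 3, which also carries a sulfur-linked chain at the same position, sits well above compound 2 in this assay. On that basis the expected step of a 2.5-fold higher number from compound 2 to compound 4 (0.40 log units; beyond the scatter) is toward a weaker inhibitor, probably beyond the scatter but not necessarily reaching the level of compound 3. Compound 4 is therefore estimated at 60000 nM in this assay, with a plausible range from 15000 nM to 250000 nM.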

Compound 4, half-maximal inhibitory concentration: 77000 nM
Beside the measured number, compound 4's estimate is 1.3-fold (0.11 log units) below it, and the stated range covers the measured number.
By their numbers in this assay, from the lowest: compound 2; then compounds 4, 1 and 3 (each within the scatter of the next).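

In this assay, going by these compounds alone, the change at this aromatic carbon gives a 3.2-fold higher number from compound 2 to compound 4 (0.51 log units; beyond the scatter), the first step that can be read at this position, and it shows that the number here responds to what is attached. Because the step changes the linking atom and the chain together and loses the hydrogen-bond donor of hexylamino, it cannot be assigned to any one of these. Nothing measured here bears on why the number rises.

Still open, from the compounds shown here alone, is whether the nitrogen link itself accounts for the lower number of compound 2, which a heptylamino chain or a hexylthio chain on the same carbon would help separate. Also open, going by these compounds, is how a sulfone, a tertiary amine or a carboxylic acid at the chain end would read at this position.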